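The source may hold more compounds than are shown below. What is called first, only, known or untested is meant among the compounds shown, and "the series" means these compounds.

Measured so far:
compound 1 `CNC(=O)/C=C1\CCc2cc(F)c(F)cc21`: 100%
compound 2 `CNC(=O)/C=C1\CCc2c(F)cc(F)cc21`: 100%
compound 3 `NC(=O)/C=C1\CCc2c(F)cc(F)cc21`: 100%

All three measured compounds sit at the top of the scale in a functional assay on the whole organism with Mus musculus as the target, at a dose of 100 mg/kg by the intraperitoneal route (on this read-out lower numbers stand for less inhibition and higher numbers for more inhibition at the one dose given (going by the name of the read-out)), with compound 1 level with compound 2 and compound 3 within the scatter. Compound 2 and compound 3 share a core; compound 3 differs from compound 2 by hydrogen in place of methyl on an amide-type nitrogen, and this step gives no change at the digits printed from compound 2 to compound 3 (within the scatter). Compound 1 and compound 2 have the same atoms joined differently; the difference between the two cores is not broken down here.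

Compound 4 `NC(=O)/C=C1\CCc2cc(F)c(F)cc21` has not yet been measured in this assay. It differs from compound 1 by hydrogen in place of methyl on an amide-type nitrogen, the same change, at the same kind of place, as that from compound 2 to compound 3. Because that earlier step gave no change at the digits printed from compound 2 to compound 3 (within the scatter), the step from compound 1 to compound 4 is expected to be no change at the digits printed from compound 1 to compound 4 (within the scatter). Among the measured compounds shown here, compound 4 is therefore estimated at 100% in this assay, with an expected range from 90% to 100%; this rests only on compound 1 and the one matched pair, so it remains to be seen.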

Compound 4, a percentage reported as inhibition, in the whole organism at one dose (the size of the read-out at that dose, not a potency): 100%
Estimate against measurement, compound 4: no gap at the digits printed, and the stated range covers the measured number.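

In this assay, hydrogen in place of methyl on an amide-type nitrogen gives no change at the digits printed from compound 1 to compound 4 (within the scatter), and the step matches the earlier one on the other core: the same change on two cores in this assay, no change at the digits printed (within the scatter) from compound 2 to compound 3 and no change at the digits printed (within the scatter) from compound 1 to compound 4, 0 percentage points apart, within the scatter of two such steps.
The change therefore carries from one core to the other without a visible difference at this one dose. All four compounds sit at the top of the scale, however, so this does not show that the two cores would respond alike at a lower dose or that potency is the same.

The compounds shown leave open how a longer chain on the amide-type nitrogen, such as ethyl or propyl, would read. They also leave open how a carboxylic acid in place of the amide would read.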